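This account rests on a few compounds, and the source may have more. Where it says the series, first, only, none or still open, it means among the compounds named here.

Compound 1 (`CCOc1c(-c2cc(OC)c(OC)c(OC)c2)oc2ccccc2c1=O`), compound 2 (`CCCOc1c(-c2cc(OC)c(OC)c(OC)c2)oc2ccccc2c1=O`) and compound 3 (`CCCCOc1c(-c2cc(OC)c(OC)c(OC)c2)oc2ccccc2c1=O`) share one core and differ only in the length of the chain on one oxygen. In a functional assay on PC-3 cells (Homo sapiens) for antiproliferative activity, read by WST assay, with a stated time of 3 days (a lower number here means a stronger inhibitor, a higher number a weaker inhibitor), compound 1 gives 900 nM as its reading, compound 2 gives 11800 nM and compound 3 gives 12800 nM on the same scale. Compound 3 thus stands level with compound 2, and both lie far from compound 1.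

Compound 4 (`CCCCCOc1c(-c2cc(OC)c(OC)c(OC)c2)oc2ccccc2c1=O`) differs from compound 3 by a single change: methyl in place of hydrogen on a saturated chain carbon, four bonds along the chain from an oxygen on an aromatic ring. Two earlier changes that lengthen the chain by one carbon bear on it. The first was large (a 13-fold higher number from compound 1 to compound 2 (1.12 log units; beyond the scatter)), whereas the next stayed within the scatter (a 1.1-fold higher number from compound 2 to compound 3 (0.04 log units; within the scatter)). Three compounds cannot show whether further lengthening will leave the number unchanged, but the later step is the closer guide, so no step beyond the scatter is expected in this assay for this change. The expected step is a 1.1-fold higher number from compound 3 to compound 4 (0.04 log units; within the scatter) by this estimate. For compound 4 the estimated value is 14000 nM with an expected range from 6000 nM to 32000 nM as its likely span.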

Compound 4, half-maximal inhibitory concentration: 22200 nM
For compound 4 the middle estimate is 1.6-fold (0.20 log units) below the measured one; measured number inside the range.
By their numbers in this assay, from the lowest: compound 1; then compounds 2, 3 and 4 (each within the scatter of the next).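

Adding a further carbon at the far end of the chain does not move the number beyond the scatter in this assay, as a 1.7-fold higher number from compound 3 to compound 4 (0.24 log units; within the scatter) and a 1.9-fold higher number from compound 2 to compound 4 (0.27 log units; within the scatter) show, so compounds 2, 3 and 4 form a level stretch with no order among them, while the distance to the shortest chain stays large at a 25-fold higher number from compound 1 to compound 4 (1.39 log units; beyond the scatter). Compound 4 therefore shows that the large change in this short series is confined to the first lengthening, and that a single added carbon does not have one fixed size of effect along this chain: the same change on two cores in this assay, a 13-fold higher number (1.12 log units; beyond the scatter) from compound 1 to compound 2 and a 1.7-fold higher number (0.24 log units; within the scatter) from compound 3 to compound 4, 7.6-fold (0.88 log units) apart, beyond the scatter of two such steps The same holds for the addition of a two-carbon piece, which is large when it is made on compound 1 and stays within the scatter when it is made on compound 2: the same change on two cores in this assay, a 14-fold higher number (1.15 log units; beyond the scatter) from compound 1 to compound 3 and a 1.9-fold higher number (0.27 log units; within the scatter) from compound 2 to compound 4, 7.6-fold (0.88 log units) apart, beyond the scatter of two such steps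

The compounds shown leave open how the number behaves with a methyl group or a bare hydroxyl on this oxygen, and whether a longer chain such as hexyl or octyl stays on the level stretch. They also leave open whether an amine or a carboxylic acid at the end of the chain would bring the number back towards that of compound 1.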